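Bromo for fluoro on a shared enone core

This account rests on a few compounds, and the source may have more. Where it says the series, first, only, none or still open, it means among the compounds named here.

Compound 1 `O=C1/C(=C/c2cccc(O)c2)CCc2cc(O)ccc21` and compound 2 `O=C1/C(=C/c2cccc(F)c2)CCc2ccc(O)cc21` were measured in a functional assay on RAW264.7 cells (Mus musculus) for inhibition; a lower number here means a stronger inhibitor, a higher number a weaker inhibitor. Compound 1 gives 3510 nM. Compound 2 gives 830 nM, the lowest of the two numbers, and the gap between these two values lies beyond the usual scatter. Compound 3 `O=C1/C(=C/c2cccc(Br)c2)CCc2ccc(O)cc21` has not yet been measured. It differs from compound 2 in one place: bromo in place of fluoro on an aromatic carbon. Within the data shown here, no step between measured compounds shows what exchanging one halogen for another does on this core, so the expectation rests on compound 2 alone. The exchange keeps a halogen in the same place and moves no donor or acceptor; the step is therefore expected to be small, at most a modest gain, and may well stay within the scatter. For compound 3 the expected step is a 1.4-fold lower number from compound 2 to compound 3 (0.14 log units; within the scatter). Compound 3 is expected to give 600 nM, within a range from 250 nM to 1800 nM.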

Compound 3, half-maximal inhibitory concentration: 480 nM
For compound 3 the middle estimate is 1.3-fold (0.10 log units) above the measured one, and the stated range covers the measured number.
By their numbers in this assay, from the lowest: compounds 3 and 2 (each within the scatter of the next); then compound 1.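

In this assay, among these compounds, bromo in place of fluoro on this aromatic carbon gives a 1.7-fold lower number from compound 2 to compound 3 (0.24 log units; within the scatter) and so gives the first direct reading of one halogen exchanged for another on the shared core. The position takes either halogen with no difference that can be told apart from the ordinary spread of repeated measurements, so compound 2 and compound 3 count as equal here. No measurement is available that would explain this result or show what lies behind it.

Going by these compounds, what chloro, the halogen not yet seen at this place, would give on the same carbon remains open, as does the effect of a non-halogen group such as methoxy, an amine or a carboxylic acid. Two halogens alone cannot establish a trend across groups at this position.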